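Phenol methylation in a sulfonamide-bearing indole oxindole pair

The source may hold more compounds than are shown below. What is called first, only, known or untested is meant among the compounds shown, and "the series" means these compounds.

Of the compounds shown here, two have numbers so far. Compound 1 `Cn1cc(/C=C2\C(=O)Nc3ccc(S(N)(=O)=O)cc32)c2ccccc21` in an assay on isolated protein for inhibition of Ephrin type-A receptor 2 (Homo sapiens), tested at 0.1 uM (on this read-out higher numbers stand for a weaker effect at the one concentration tested and lower numbers for a stronger effect), gives 99%. Compound 2 `CN(C)S(=O)(=O)c1ccc2c(c1)/C(=C/c1cn(C)c3ccc(O)cc13)C(=O)N2` in this assay gives 111%, the highest of the two numbers, with compound 1 standing a step lower that is beyond the scatter. Both numbers sit close to full activity, so neither compound shows much inhibition at the single concentration tested.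

Compound 3 `COc1ccc2c(c1)c(/C=C1\C(=O)Nc3ccc(S(=O)(=O)N(C)C)cc31)cn2C` has not yet been measured. It differs from compound 2 by methyl in place of hydrogen on an oxygen on an aromatic ring. Going by the values given here, no step between measured compounds bears on this change, so nothing sets its size or direction.

With compound 2 already near the ceiling of the read-out, the step is expected to be small, a number 8 percentage points lower from compound 2 to compound 3 (within the scatter), and not beyond the scatter in either direction. For compound 3 in this assay the estimate is 103%, with a range from 88% to 118%.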

Compound 3, a percentage reported as activity, at one concentration (the size of the read-out at that concentration, not a potency): 106%
The estimate for compound 3 lay 3 percentage points below the measured number; the range from low to high includes it.
By their numbers in this assay, from the lowest: compounds 1, 3 and 2 (each within the scatter of the next, the first and the last beyond it).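

In this assay, going by these compounds alone, the change from hydroxy to methoxy gives a number 5 percentage points lower from compound 2 to compound 3 (within the scatter) and so provides the first step that can be read directly. Capping this oxygen with methyl therefore produces no difference that this read-out can separate at the one concentration tested, but both compounds show little inhibition, so the step cannot show how the change would behave in a compound with a clear effect. No available measurement bears on the reason for this result.

From the compounds shown here alone, it remains open whether an ethyl group or a longer chain on this oxygen, or an amine or a carboxylic acid in place of the hydroxy, would move the number beyond the scatter. The same change also remains to be read on a compound carrying the unsubstituted sulfonamide of compound 1.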